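A few compounds are considered here, and "the series" means these few. Any claim that something is new, unique, unknown or untested is made for them only; others in the source may bear on it.

Compound 3 `CC1(C)CC12NC(=O)N(NC(=O)c1ccc(F)cc1)C2=O` gives 100 mg/kg in a functional assay on the whole organism (Hindlimb) for inhibition, with Mus musculus as the target, with a stated time of 0.5 h (on this read-out higher numbers stand for an effect only at larger amounts of compound and lower numbers for an effect already at smaller amounts), the second highest of the three numbers recorded. Compound 1 `CC(C)(C)c1ccc(C(=O)NN2C(=O)NC3(CC3(C)C)C2=O)cc1` gives 30 mg/kg, and compound 2 `CC1(C)CC12NC(=O)N(NC(=O)c1ccccc1Cl)C2=O` gives 300 mg/kg. One step, a 3.3-fold higher number from compound 1 to compound 3 (0.52 log units; beyond the scatter), shows that putting fluoro in place of tert-butyl on the aromatic carbon raised the number; the other step, a 3.0-fold lower number from compound 2 to compound 3 (0.48 log units; beyond the scatter), concerns a different part of the molecule. Compound 4 `CN(C)c1ccc(C(=O)NN2C(=O)NC3(CC3(C)C)C2=O)cc1` differs from compound 3 in one place: dimethylamino in place of fluoro on an aromatic carbon. Only the first of these steps bears on this change; dimethylamino, like tert-butyl, brings more heavy atoms to that aromatic carbon than fluoro does, so a modest lowering of the number is expected, a 2.0-fold lower number from compound 3 to compound 4 (0.30 log units; within the scatter). Compound 4 is estimated at 50 mg/kg, with a range from 20 mg/kg to 150 mg/kg.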

Compound 4, minimum effective dose: 300 mg/kg
Compound 4: the middle estimate sits 6.0-fold (0.78 log units) below what was measured, outside the stated range (above it).
By their numbers in this assay, from the lowest: compound 1; then compound 3; then compounds 2 and 4 (each within the scatter of the next).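

Dimethylamino in place of fluoro on this aromatic carbon moves the number the same way as removing tert-butyl did, with a 3.0-fold higher number from compound 3 to compound 4 (0.48 log units; beyond the scatter), so bringing more heavy atoms here does not by itself lower it. The two larger groups also differ sharply, with a 10-fold higher number from compound 1 to compound 4 (1.00 log units; beyond the scatter), which means tert-butyl gives the lowest number of the three groups compared at this carbon. Nothing measured here explains that gap. As far as these compounds go, whether a methoxy group, a chlorine or a simple amine at this carbon would fall nearer compound 1 or compound 4 remains open.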